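The source may hold more compounds than are shown below. What is called first, only, known or untested is meant among the compounds shown, and "the series" means these compounds.

Measured compounds:
Compound 1 `CCCCCCCCCCc1ccc(-c2noc(C3CNC3)n2)cc1` gives 65% in an assay on HeLa cells for inhibition of sphingosine-1-phosphate transporter SPNS2 (Mus musculus), read by LC-MS, tested at 2 uM; a lower number here means less inhibition, a higher number more inhibition at the concentration tested (going by the name of the read-out).
Compound 2 `CCCCCCCCCCc1ccc(-c2noc([C@@H]3CC[C@H](N)C3)n2)cc1` gives 38% in this assay.

Among these two numbers compound 2 stands lowest: its nearest neighbour is compound 1, and the only measured step, a number 27 percentage points lower from compound 1 to compound 2 (beyond the scatter), is described as modest but beyond the scatter. Compound 3 `CCCCCCCCCCc1ccc(-c2noc(CC[C@@H](N)C(=O)O)n2)cc1` has not yet been measured. The change from compound 2 to compound 3 is 3-amino-3-carboxypropyl in place of 3-aminocyclopentyl on an aromatic carbon. No measured step concerns this change: the one step shown swaps one ring-bearing amine for another, whereas here the ring leaves and an open 3-amino-3-carboxypropyl enters. The earlier step therefore gives only a sense of scale, showing that a change at this position moved the read-out modestly. Without a directly comparable step, the expected outcome for compound 3 is uncertain in direction, and a step of about a number 7 percentage points higher from compound 2 to compound 3 (within the scatter) is estimated, which is within the scatter. For compound 3 in this assay a value of 45% is expected, with a range from 15% to 75%.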

Compound 3, a percentage reported as inhibition, at one concentration (the size of the read-out at that concentration, not a potency): 5%
Compound 3: the middle estimate sits 40 percentage points above what was measured, and the stated range ends above it.
By their numbers in this assay, from the lowest: compound 3; then compound 2; then compound 1.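

In this assay, replacing the ring of compound 2 with the open 3-amino-3-carboxypropyl gives a number 33 percentage points lower from compound 2 to compound 3 (beyond the scatter). Against the azetidin-3-yl of compound 1, the same group gives a number 60 percentage points lower from compound 1 to compound 3 (beyond the scatter), which places compound 3 lowest of the three, with both steps beyond the scatter and both large. All three groups carry an amino group, so the earlier pair showed only a shift between two ring-bearing amines, whereas compound 3 shows that an amino group at this position does not by itself keep the read-out up, and nothing available here explains the fall.

The change from compound 2 to compound 3 removes the ring and brings in a carboxylic acid in a single step, so these compounds cannot say which of the two matters: a simple open-chain amine such as 3-aminopropyl, or a ring-bearing amino acid such as a carboxyazetidine, would separate them. Going by these compounds, it also remains open how a six-membered amine such as piperidin-4-yl or a longer amine chain would read in this assay.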